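Swapping an indenylethyl amide for a Boc-aminoethyl amide

The source may report more compounds than this note shows. Statements on the series, on what has been measured and on what is new or still open speak of the compounds shown alone.

Of the compounds shown here, two sharing one core have been measured so far. Compound 1 `CCCSc1nc(Cl)c2c(n1)N(Cc1ccccc1)C(C(=O)O)N2` carries a free carboxylic acid, and in a functional assay on A549 cells (Homo sapiens) for antiproliferative activity, read by MTT assay, with a stated time of 72 h (a lower number here means a stronger inhibitor, a higher number a weaker inhibitor), compound 1 gives 10700 nM. Compound 2 `CCCSc1nc(Cl)c2c(n1)N(Cc1ccccc1)C(C(=O)NCCC1=CCc3ccccc31)N2` is the corresponding amide, and in this assay compound 2 gives 48800 nM. Compound 2 thus holds the highest number of the two; the gap to compound 1 lies beyond the scatter, so compound 2 is the weaker of the pair.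

Compound 3 `CCCSc1nc(Cl)c2c(n1)N(Cc1ccccc1)C(C(=O)NCCNC(=O)OC(C)(C)C)N2` keeps the amide of compound 2 but differs in one place: a group of 8 heavy atoms (5 carbon, 1 nitrogen, 2 oxygen; no ring) in place of a group of 9 heavy atoms (9 carbon; one five-membered non-aromatic ring of carbon only, one six-membered aromatic ring of carbon only), on a saturated chain carbon, two bonds along the chain from an amide-type nitrogen. Going by the values given here, no measured pair shows what such a change does on this core, so the expectation rests on the two values alone. Both measured compounds sit at high numbers, and the amide of compound 2 did not bring a lower number than the acid of compound 1. Compound 3 is therefore expected to remain a weak inhibitor, and the step of a 1.4-fold lower number from compound 2 to compound 3 (0.14 log units; within the scatter) is estimated to be small, within or near the scatter. Compound 3 is expected to give about 35000 nM, with a range from 12000 nM to 100000 nM.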

Compound 3, half-maximal inhibitory concentration: 53200 nM
Compound 3: the middle estimate sits 1.5-fold (0.18 log units) below what was measured; measured number inside the range.
By their numbers in this assay, from the lowest: compound 1; then compounds 2 and 3 (each within the scatter of the next).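

In this assay, (tert-butoxycarbonyl)amino in place of the indenyl group, on a saturated chain carbon two bonds along the chain from an amide-type nitrogen, gives a 1.1-fold higher number from compound 2 to compound 3 (0.04 log units; within the scatter). The two groups differ in their rings and in their hydrogen-bond donors and acceptors, yet this step shows no difference in antiproliferative read-out that can be told from the scatter. The second step, (2-((tert-butoxycarbonyl)amino)ethyl)amino in place of hydroxy on a carbonyl carbon, gives a 5.0-fold higher number from compound 1 to compound 3 (0.70 log units; beyond the scatter), so both amides shown now stand at higher numbers than the free carboxylic acid of compound 1, with neither going against this, and nothing measured here accounts for the result.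

Two amides cannot show whether the higher numbers belong to the amide link itself or to the particular chains it carries, and a plain methyl amide or a free primary amine at the end of the ethyl chain would bear on that. Going by these compounds, how a longer chain would behave at this place also remains open, as does whether any such amide could reach a number below that of the acid.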